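This account rests on a few compounds, and the source may have more. Where it says the series, first, only, none or still open, it means among the compounds named here.

Measured compounds:
- Compound 1 `Cc1cc(C)cc(S(=O)(=O)c2c(C(=O)N[C@H]3CCNC3)[nH]c3ccc(Cl)cc23)c1`: 10000 nM
- Compound 2 `Cc1cc(C)cc(S(=O)(=O)c2c(C(=O)NC3CN(Cc4n[nH]c(=O)n4C)C3)[nH]c3ccc(Cl)cc23)c1`: 25200 nM

In an ADME assay on MT4 cells (Homo sapiens) for cytotoxicity, read by MTT assay, with a stated time of 5 days (a higher number here means that more compound is tolerated, a lower number that less compound is tolerated), compound 2 gives 25200 nM, the higher of the two numbers, while compound 1 gives 10000 nM. Compound 3 `CCS(=O)(=O)NC(=O)c1[nH]c2ccc(Cl)cc2c1S(=O)(=O)c1cc(C)cc(C)c1` differs from compound 2 on the amide-type nitrogen: a group of 5 heavy atoms (2 carbon, 2 oxygen, 1 sulfur; no ring) in place of a group of 12 heavy atoms (7 carbon, 4 nitrogen, 1 oxygen; one four-membered non-aromatic ring with 1 hetero atom, one five-membered aromatic ring with 3 hetero atoms), on an amide-type nitrogen. An ethylsulfonyl group enters there, and that substituent no longer carries a ring.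

Among the compounds with values here, only one measured step bears on this change, as it also alters the group on the same nitrogen: a 2.5-fold higher number from compound 1 to compound 2 (0.40 log units; beyond the scatter). It is modest but beyond the scatter. Within the data shown here, no measured compound carries an ethylsulfonyl group, so this single step offers a guide to size and only a weak hint of direction. The smaller group in compound 1 goes with the lower value of 10000 nM, so a modest move toward a lower number is expected in this assay, although a move in the other direction cannot be excluded. The expected change is a 1.4-fold lower number from compound 2 to compound 3 (0.15 log units; within the scatter). For compound 3 the estimated value is 18000 nM, with an expected range from 6000 nM to 60000 nM.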

Compound 3, half-maximal cytotoxic concentration: > 283000 nM
Compound 3 ended at the assay's limit (the forecaster's own chance of this, stated with the estimate: 25%); middle value at least 15-fold (1.19 log units) from the limit.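

Within the data shown here, at the amide-type nitrogen, ethylsulfonyl gives an at least 11-fold higher number from compound 2 to compound 3 (1.05 log units; beyond the scatter) in this assay, and against the pyrrolidin-3-yl group it gives an at least 28-fold higher number from compound 1 to compound 3 (1.45 log units; beyond the scatter); both steps are large, whereas the only earlier step at this position was a 2.5-fold higher number from compound 1 to compound 2 (0.40 log units; beyond the scatter). This position can therefore move the number in this assay much further than the earlier pair showed, and heavy-atom count alone does not order the compounds: the groups of compound 1 and compound 3 both hold 5 heavy atoms yet lie at opposite ends of the series, so the earlier pairing of the smaller group with the lower number does not hold for compound 3. Compound 3 stands at a limit of the assay, not at a number: the limit of > 283000 nM in this assay, at which 1 of the 3 values shown sits.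

As far as these compounds go, how far the number of compound 3 lies past that limit stays open, and so does the full size of both new steps. Also open, from the compounds shown here alone, is which part of the ethylsulfonyl group goes with the rise, a question that an acetyl or methylsulfonyl group, or an open-chain amine, on the same nitrogen would bear on.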